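Ether-to-carbamate swap on the shared core: expectation

A few compounds are considered here, and "the series" means these few. Any claim that something is new, unique, unknown or untested is made for them only; others in the source may bear on it.

Measured so far:
- compound 1 `CC(C)=CCOc1cc(=O)n(CCCO)c2c1CC(CC=C(C)C)C(C)(C)C2`: in a functional assay on PANC-1 cells (Homo sapiens) for inhibition, read by MTT assay, with a stated time of 24 h, tested at 10 uM (on this read-out lower numbers stand for less inhibition and higher numbers for more inhibition at the one concentration tested (going by the name of the read-out)), compound 1 gives 7.5%
- compound 2 `COc1ccc(OCCCOc2cc(=O)n(CCCO)c3c2CC(CC=C(C)C)C(C)(C)C3)cc1`: in this assay compound 2 gives 4.1%
- compound 3 `CC(C)=CCC1Cc2c(OCCCOc3ccc([N+](=O)[O-])cc3)cc(=O)n(CCCO)c2CC1(C)C`: in this assay compound 3 gives 0%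

Compound 1 holds the highest of the three numbers, yet the steps of a number 3.4 percentage points lower from compound 1 to compound 2 (within the scatter) and a number 7.5 percentage points lower from compound 1 to compound 3 (within the scatter) are both within the scatter, and a number 4.1 percentage points lower from compound 2 to compound 3 (within the scatter) is likewise, so the three compounds cannot be told apart on this read-out.

Compound 4 `COc1cccc(NC(=O)Oc2cc(=O)n(CCCO)c3c2CC(CC=C(C)C)C(C)(C)C3)c1` differs from compound 1 in one place: (3-methoxyphenyl)carbamoyl in place of 3-methylbut-2-en-1-yl on an oxygen on an aromatic ring. The measured steps all alter the chain on the saturated carbon bound to the aromatic oxygen, or a substituent on the added aromatic ring; none replaces the chain with a carbamoyl group on that oxygen. They bear on the new step only in that every change made at this part of the shared core has left the read-out within the scatter. On that basis the step of a number 1.5 percentage points lower from compound 1 to compound 4 (within the scatter) is expected to be none beyond the scatter. Compound 4 is therefore estimated at 6%, with a range from 0% to 20% expected.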

Compound 4, a percentage reported as inhibition, at one concentration (the size of the read-out at that concentration, not a potency): 0%
Estimate against measurement, compound 4: 6 percentage points above; the range from low to high includes it.
By their numbers in this assay, from the lowest: compounds 3, 4, 2 and 1 (each within the scatter of the next).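

In this assay, the carbamoyl exchange gives a number 7.5 percentage points lower from compound 1 to compound 4 (within the scatter). The oxygen on the aromatic ring thus carries a carbamoyl group as well as ether-linked chains, and this change of linkage still leaves no step beyond the scatter. The entering (3-methoxyphenyl)carbamoyl group has 11 heavy atoms, one six-membered aromatic ring and 1 hydrogen-bond donor, against 5 heavy atoms, no ring and 0 hydrogen-bond donors in the leaving 3-methylbut-2-en-1-yl, yet this larger change in composition likewise gives no separation on this read-out, and no measurement bears on why.

As far as these compounds go, whether any group on this oxygen can move the read-out beyond the scatter stays open, for example a carbamoyl group carrying a morpholine ring, or a longer chain ending in a carboxylic acid. The four compounds also leave open whether the 3-methoxyphenyl group matters within the carbamoyl group, since no second carbamoyl compound is shown.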